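Halogenated anilines on a shared core: next step

A few compounds are considered here, and "the series" means these few. Any claim that something is new, unique, unknown or untested is made for them only; others in the source may bear on it.

Among the compounds with values here, compound 2 `CN1CCN(CCCOc2cccc3nc(Nc4cc(Cl)cc(Cl)c4)ccc23)CC1` gives the lowest of the two numbers measured so far in a functional assay on cells (Panel renal (Carcinoma cell lines), Homo sapiens) for inhibition, read by sulforhodamine B assay, with a stated time of 48 h (a lower number here means a stronger inhibitor of growth, a higher number a weaker inhibitor of growth), at 2070 nM. Within the data shown here, its nearest neighbour is compound 1 `CN1CCN(CCCOc2cccc3nc(Nc4ccc(F)c(F)c4)ccc23)CC1`, which in this assay gives 4160 nM; the only step between measured compounds, a 2.0-fold lower number from compound 1 to compound 2 (0.30 log units; within the scatter), stays within the scatter. Compound 3 `CN1CCN(CCCOc2cccc3nc(Nc4ccc(Cl)c(F)c4)ccc23)CC1` is the next member of the series and has not yet been measured. It differs from compound 2 by 4-chloro-3-fluorophenyl in place of 3,5-dichlorophenyl on a nitrogen on an aromatic ring. Among the measured compounds shown here, the single step that bears on this change is a 2.0-fold lower number from compound 1 to compound 2 (0.30 log units; within the scatter), and it was small. Compound 3 carries one fluorine and one chlorine on the phenyl ring, between the halogen patterns of compound 1 and compound 2, so no step beyond the scatter is expected; the estimated change is a 1.4-fold higher number from compound 2 to compound 3 (0.15 log units; within the scatter). Compound 3 is therefore expected to give about 2900 nM in this assay, with a range of 1200 nM to 7000 nM.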

Compound 3, concentration for 50% growth inhibition: 2220 nM
Compound 3: middle estimate off by 1.3-fold (0.12 log units), on the high side; low and high end bracket the measured number.
By their numbers in this assay, from the lowest: compounds 2, 3 and 1 (each within the scatter of the next).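

In this assay, 4-chloro-3-fluorophenyl in place of 3,5-dichlorophenyl on a nitrogen on an aromatic ring gives a 1.1-fold higher number from compound 2 to compound 3 (0.03 log units; within the scatter), so this change in halogen pattern leaves no readable difference. Within the data shown here, the single exchange of chloro in place of fluoro on an aromatic carbon gives a 1.9-fold lower number from compound 1 to compound 3 (0.27 log units; within the scatter), and with this step the three halogenated phenyl groups at this position are not separated by this assay. No measurement at hand accounts for this result.

As far as these compounds go, whether a group other than a halogen on this phenyl ring, such as methoxy, nitrile or an amine, would give a step beyond the scatter remains open. Also open, from the compounds shown here alone, is whether an unsubstituted phenyl would read differently from these three compounds.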